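This account rests on a few compounds, and the source may have more. Where it says the series, first, only, none or still open, it means among the compounds named here.

Compound 1 `N#CC1=C(/N=C/Nc2ccc([N+](=O)[O-])cc2)N(c2ccccc2)C(=O)N2CCCCC(N3CCCC3)C12` gives 85.6% in a functional assay on the whole organism (strain albino) for inhibition, with Rattus norvegicus as the target, read by paw edema, with stated times of 1 h and 3 h, at a dose of 20 mmol/kg by the intraperitoneal route; a lower number here means a weaker effect, a higher number a stronger effect of the compound at the dose given. Compound 2 `N#CC1=C(NC(=O)c2ccccc2O)N(c2ccccc2)C(=O)N2CCCCC(N3CCCC3)C12` gives 65.4% in this assay, the lower of the two numbers shown, after a step that is a number 20.2 percentage points lower from compound 1 to compound 2 (beyond the scatter). Compound 3 `N#CC1=C(NCC(=O)N2CCCCC2)N(c2ccccc2)C(=O)N2CCCCC(N3CCCC3)C12` differs from compound 2 in one place: ((piperidin-1-yl)carbonyl)methyl in place of (2-hydroxyphenyl)carbonyl on an amine nitrogen. Going by the values given here, only one measured step bears on this change, the earlier exchange of the group on the double-bonded ring carbon, which ran a number 20.2 percentage points lower from compound 1 to compound 2 (beyond the scatter); it shows that exchanging the group at this place moves the number by a modest amount, and nothing measured tells which direction the entering group will take. The expectation is therefore that compound 3 sits near compound 2, with a step of a number 5.4 percentage points lower from compound 2 to compound 3 (within the scatter) that is estimated to stay within or only just beyond the scatter. The estimate for compound 3 in this assay is 60%, expected to fall between 40% and 80%.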

Compound 3, a percentage reported as inhibition, in the whole organism at one dose (the size of the read-out at that dose, not a potency): 53.5%
Compound 3: middle estimate off by 6.5 percentage points, on the high side; the measured number falls inside the stated range.
By their numbers in this assay, from the lowest: compound 3; then compound 2; then compound 1.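

Going by these compounds alone, putting ((piperidin-1-yl)carbonyl)methyl in place of (2-hydroxyphenyl)carbonyl on an amine nitrogen gave a number 11.9 percentage points lower from compound 2 to compound 3 (beyond the scatter) in this assay and so supplied a direction for this exchange, which the earlier compounds could not give. Set against compound 1, the same place shows a number 32.1 percentage points lower from compound 1 to compound 3 (beyond the scatter) and this shows that the group on the double-bonded ring carbon can move the read-out by a large amount, not only a modest one. Nothing available accounts for these differences.

The compounds shown leave open how a simple amine or a carboxylic acid would fare on the amine nitrogen, and whether a longer chain in place of the methyl in ((piperidin-1-yl)carbonyl)methyl would change the number. They also leave open which part of the group in compound 1 goes with its higher number.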